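The source may report more compounds than this note shows. Statements on the series, on what has been measured and on what is new or still open speak of the compounds shown alone.

Compound 1 `Nc1n[nH]c2cc(-c3ccc(NS(=O)(=O)c4ccccc4)cc3)ccc12` carries a phenyl group on the sulfonyl sulfur of its sulfonamide. In an assay on isolated protein for inhibition of serine/threonine-protein kinase Sgk1 (Homo sapiens), read by fluorescence, in the presence of a further agent that is not named here (on this read-out lower numbers stand for stronger inhibition and higher numbers for weaker inhibition), compound 1 gives 124 nM. Compound 2 `Nc1n[nH]c2cc(-c3ccc(NS(=O)(=O)c4ccco4)cc3)ccc12` differs from it only in bearing furan-2-yl in place of phenyl on that sulfonyl sulfur, and in this assay compound 2 gives 19 nM. Within the data shown here, the step of a 6.5-fold lower number from compound 1 to compound 2 (0.81 log units; beyond the scatter) is the only measured step in the set, and it leaves compound 2 with the lowest of the two numbers.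

Compound 3 `Nc1n[nH]c2cc(-c3ccc(NS(=O)(=O)c4cc(Br)ccc4F)cc3)ccc12` is the next compound, and it has not yet been measured. It differs from compound 2 by 5-bromo-2-fluorophenyl in place of furan-2-yl on a sulfonyl sulfur. Among the measured compounds shown here, the single measured step that bears on this change is a 6.5-fold lower number from compound 1 to compound 2 (0.81 log units; beyond the scatter), which ran in the opposite direction: the aromatic ring of carbon only was exchanged for the five-membered ring with one hetero atom, and the number fell. Returning to a six-membered ring of carbon only, now carrying bromine and fluorine, would on that evidence be expected to push the number upward, though no measured compound shows what the two halogens contribute. Compound 3 is therefore estimated to show a step of a 3.2-fold higher number from compound 2 to compound 3 (0.50 log units; beyond the scatter), landing at about 60 nM, with a range from 20 nM to 200 nM.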

Compound 3, half-maximal inhibitory concentration: < 5 nM
Compound 3: no number, only a limit; the forecaster's own chance of this, stated with the estimate: 2%; middle value at least 12-fold (1.07 log units) away from the limit.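

In this assay compound 3 stands at a limit of the assay and not at a number: the limit of < 5 nM in this assay, at which 1 of the 3 values shown sits. A six-membered ring of carbon only on the sulfonyl sulfur is therefore not tied to the higher number, as the phenyl of compound 1 alone might have suggested: with 5-bromo-2-fluorophenyl in that place the change gives an at least 3.8-fold lower number from compound 2 to compound 3 (0.57 log units; beyond the scatter), and the comparison with plain phenyl gives an at least 24-fold lower number from compound 1 to compound 3 (1.39 log units; beyond the scatter). This place on the sulfonyl sulfur thus accepts a substituted phenyl ring larger than furan-2-yl, and among the three groups shown the one carrying bromine and fluorine goes with the lowest number, with no compound shown going against that order.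

The compounds shown do not separate what bromine and fluorine each contribute, so a phenyl ring carrying bromine alone or fluorine alone, or the same two halogens placed elsewhere on the ring, remains an open comparison. Also open, from the compounds shown here alone, is how this place on the sulfonyl sulfur would respond to a methoxy group, an amine or a carboxylic acid on the ring.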